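This account rests on a few compounds, and the source may have more. Where it says the series, first, only, none or still open, it means among the compounds named here.

Measured so far in an ADME assay on NIH3T3 cells (Mus musculus) for cytotoxicity, read by MTT assay, with a stated time of 24 h; on this read-out lower numbers stand for stronger inhibition and higher numbers for weaker inhibition:
Compound 1 `O=C(CSc1nnc(-c2ccncc2)o1)N/N=C/c1ccc(Br)cc1` gives 169000 nM
Compound 2 `COc1ccc(/C=N/NC(=O)CSc2nnc(-c3ccncc3)o2)cc1` gives 132000 nM
Compound 3 `O=C(CSc1nnc(-c2ccncc2)o1)N/N=C/c1ccccc1[N+](=O)[O-]` gives 214000 nM

Compound 1 stands second highest of these three numbers, and its gaps to both neighbours are within the scatter: a 1.3-fold higher number from compound 1 to compound 3 (0.10 log units; within the scatter) and a 1.3-fold lower number from compound 1 to compound 2 (0.11 log units; within the scatter). Compound 4 `O=C(CSc1nnc(-c2ccncc2)o1)N/N=C/C=C/c1ccccc1` has not yet been tested. Its change from compound 1 is 2-phenylethenyl in place of 4-bromophenyl on a carbon with a double bond to nitrogen. Among the measured compounds shown here, no measured step swaps this part for an open chain carrying a phenyl ring; the steps that do vary the group on the carbon with a double bond to nitrogen, a 1.3-fold lower number from compound 1 to compound 2 (0.11 log units; within the scatter), a 1.3-fold higher number from compound 1 to compound 3 (0.10 log units; within the scatter) and a 1.6-fold higher number from compound 2 to compound 3 (0.21 log units; within the scatter), all stay within the scatter. So no step beyond the scatter is expected in this assay, in either direction. Compound 4 is therefore estimated at 170000 nM, within 90000 nM to 320000 nM. That estimate means an expected step of a 1.0-fold higher number from compound 1 to compound 4 (0.00 log units; within the scatter).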

Compound 4, half-maximal inhibitory concentration: 160000 nM
Compound 4: middle estimate off by 1.1-fold (0.03 log units), on the high side, and the stated range covers the measured number.
By their numbers in this assay, from the lowest: compounds 2, 4, 1 and 3 (each within the scatter of the next).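

In this assay, the open 2-phenylethenyl chain on the carbon with a double bond to nitrogen gives a 1.1-fold lower number from compound 1 to compound 4 (0.02 log units; within the scatter) and a 1.3-fold lower number from compound 3 to compound 4 (0.13 log units; within the scatter) and a 1.2-fold higher number from compound 2 to compound 4 (0.08 log units; within the scatter). So, among these four compounds, an open chain carrying a phenyl ring cannot be told apart from 4-bromophenyl, 2-nitrophenyl or 4-methoxyphenyl at this position. Nothing available gives a reason for these numbers lying so close.

Going by these compounds, whether any group here can produce a step beyond the scatter stays open, for instance a carboxylic acid, an amine or a longer chain without a phenyl ring.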